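Compound 4: Pyrrolidin-1-yl in Place of Piperidin-1-yl

The compounds below may be only part of what the source reports. "The series", "measured", "known", "first", "only" and "open" are said of these compounds alone.

The measured compounds:
compound 1, `c1cc(N2CCCCC2)nc(Nc2ccc(Oc3ncnc4sccc34)cc2)n1`, 66.3%
compound 2, `CNC(=O)c1cc(Oc2ccc(Nc3nccc(N4CCCCC4)n3)cc2)ccn1`, 69.8%
compound 3, `CN(c1ccc(Oc2ncnc3sccc23)cc1)c1nccc(N2CCCCC2)n1`, 52.2%

In a functional assay on HCT-116 cells (Homo sapiens) for inhibition, read by MTT assay, with a stated time of 72 h, tested at 20 uM (a lower number here means less inhibition, a higher number more inhibition at the concentration tested (going by the name of the read-out)), compound 1 gives 66.3%, the second highest of the three numbers. Its nearest neighbour is compound 2, with a step of a number 3.5 percentage points higher from compound 1 to compound 2 (within the scatter); the furthest is compound 3, with a step of a number 14.1 percentage points lower from compound 1 to compound 3 (beyond the scatter).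

Compound 4, `c1cc(N2CCCC2)nc(Nc2ccc(Oc3ncnc4sccc34)cc2)n1`, has not yet been measured. It differs from compound 1 in one place: pyrrolidin-1-yl in place of piperidin-1-yl on an aromatic carbon.

Neither measured step bears directly on this change. The step from compound 1 to compound 2 exchanges the group on the ether oxygen and stays within the scatter; the step from compound 1 to compound 3 adds a methyl on the nitrogen and lowers the number modestly. Nothing measured here touches the piperidin-1-yl group itself, so no direction can be drawn from the data, and the expectation for this assay is a step no larger than the scatter, a number 2.3 percentage points lower from compound 1 to compound 4 (within the scatter).

Compound 4 is therefore estimated at 64%, with a range from 50% to 78%.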

Compound 4, a percentage reported as inhibition, at one concentration (the size of the read-out at that concentration, not a potency): 54.4%
Compound 4: the middle estimate sits 9.6 percentage points above what was measured; low and high end bracket the measured number.
By their numbers in this assay, from the lowest: compounds 3 and 4 (each within the scatter of the next); then compounds 1 and 2 (each within the scatter of the next).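

In this assay, the change at this position gives a number 11.9 percentage points lower from compound 1 to compound 4 (beyond the scatter), so the amine ring on the aromatic carbon next to the ring nitrogen is not a silent place in this series. The earlier steps shown here altered only the group on the ether oxygen and the nitrogen on the aromatic ring, whereas this one shows that removing a single ring carbon, going from piperidin-1-yl to pyrrolidin-1-yl, is enough to move the number beyond the scatter. Nothing available here explains this step.

The compounds shown leave open how a morpholine ring, an azepane ring or an open-chain dimethylamino group would read at this position. They also leave open whether pyrrolidin-1-yl would give a similar step with the ether group of compound 2 in place.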